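The source may report more compounds than this note shows. Statements on the series, on what has been measured and on what is new or still open speak of the compounds shown alone.

Compound 1 `COc1cc(OC)c(-c2coc3cc(OCC=C(C)C)ccc3c2=O)cc1OC`: 1580 nM
Compound 2 `COc1cc(OC)c(-c2coc3cc(OCc4ccccc4)ccc3c2=O)cc1OC`: 1640 nM
Compound 3 `COc1cc(OC)c(-c2coc3cc(OCc4ccccc4C#N)ccc3c2=O)cc1OC`: 990 nM

All three values come from a functional assay on A-375 cells (Homo sapiens) for antiproliferative activity, read by MTT assay, with a stated time of 24 h; a higher number here means a weaker inhibitor, a lower number a stronger inhibitor. Going by the values given here, compound 3, at 990 nM, lies within the scatter of both other compounds, so the numbers so far do not separate the three.

The next compound, compound 4 `COc1cc(OC)c(-c2coc3cc(OCc4ccc(Cl)cc4)ccc3c2=O)cc1OC`, keeps the shared core and differs from compound 3 in one group: 4-chlorophenyl in place of 2-cyanophenyl on a saturated chain carbon bound to an oxygen on an aromatic ring. The 4-chlorophenyl stands in place of the 2-cyanophenyl on a saturated chain carbon bound to an oxygen on an aromatic ring.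

Among the compounds with values here, three measured steps bear on this change. The closest is a 1.7-fold lower number from compound 2 to compound 3 (0.22 log units; within the scatter), which is cyano in place of hydrogen on an aromatic carbon, and compound 4 gives up that cyano. Exchanging the whole group on the same chain carbon gave a 1.0-fold higher number from compound 1 to compound 2 (0.02 log units; within the scatter) and a 1.6-fold lower number from compound 1 to compound 3 (0.20 log units; within the scatter). All three steps stay within the scatter. Within the data shown here, no measured compound carries a 4-chlorophenyl, so the data do not test that group directly.

On this evidence, no step beyond the scatter is expected in this assay, and no direction can be firmly assigned. The estimated step is a 1.3-fold higher number from compound 3 to compound 4 (0.12 log units; within the scatter). For compound 4 the expected value is 1300 nM, with an estimated range from 650 nM to 2600 nM.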

Compound 4, half-maximal inhibitory concentration: 1020 nM
Compound 4: middle estimate off by 1.3-fold (0.11 log units), on the high side; the measured number falls inside the stated range.
By their numbers in this assay, from the lowest: compounds 3, 4, 1 and 2 (each within the scatter of the next).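

In this assay, the 4-chlorophenyl and the 2-cyanophenyl on this saturated chain carbon are not told apart, with a 1.0-fold higher number from compound 3 to compound 4 (0.01 log units; within the scatter) for the exchange. The chloro group on the aromatic ring adds a second substituent at this place and, like the cyano group, it does not clear the scatter: the step from the unsubstituted phenyl is a 1.6-fold lower number from compound 2 to compound 4 (0.21 log units; within the scatter), and the step from the 2-methylprop-1-en-1-yl group is a 1.5-fold lower number from compound 1 to compound 4 (0.19 log units; within the scatter). All four compounds therefore remain unseparated, so this place has tolerated an alkenyl group, a plain phenyl and two substituted phenyl groups without a step beyond the scatter, and nothing in the data offers a reason for these steps.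

The compounds shown leave open whether a step beyond the scatter can be reached here at all, for instance with an amine or a carboxylic acid on the aromatic ring, or with a longer chain in place of the single saturated carbon. They also leave open whether these results hold for a core without the methoxy groups, since all four compounds share them.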